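A Hydroxy Group Transferred Between Two Related Cores

A few compounds are considered here, and "the series" means these few. Any claim that something is new, unique, unknown or untested is made for them only; others in the source may bear on it.

Three compounds have so far been measured in a functional assay on cells (Cancer cell lines, Homo sapiens) for inhibition, with a stated time of 48 h; on this read-out lower numbers stand for stronger inhibition of growth and higher numbers for weaker inhibition of growth:

compound 1, `COc1cc2c(/C=C3/C(=O)N(C)c4ccccc43)c(Cl)n(C)c2cc1C`, 4470 nM
compound 2, `COc1cc2c(/C=C3/C(=O)N(C)c4ccc(O)cc43)c(Cl)n(C)c2cc1C`, 1740 nM
compound 3, `COc1cc2c(/C=C3/C(=O)N(C)c4ccccc43)c[nH]c2cc1C`, 42700 nM

Compound 2 differs from compound 1 by one change, (hydroxy in place of hydrogen on an aromatic carbon). In this assay this change produced a 2.6-fold lower number from compound 1 to compound 2 (0.41 log units; beyond the scatter). Compound 3 carries a different core; the difference between the core of compound 1 and that of compound 3 is not broken down here. Compound 3 gives the highest number of the three, and its values against compound 1 and compound 2 both lie well beyond the usual scatter of the measurement.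

Compound 4, `COc1cc2c(/C=C3/C(=O)N(C)c4ccc(O)cc43)c[nH]c2cc1C`, has not yet been measured. It stands to compound 3 as compound 2 stands to compound 1: it differs by hydroxy in place of hydrogen on an aromatic carbon, the same change in the same place on the ring, and among the compounds shown this change occurs twice in all.

Among the compounds with values here, the only guide to what compound 4 may show is the first occurrence of the change. For compound 4 the step of a 2.5-fold lower number from compound 3 to compound 4 (0.40 log units; beyond the scatter) is expected in this assay because a 2.6-fold lower number from compound 1 to compound 2 (0.41 log units; beyond the scatter) was seen when the hydroxy group was introduced on the core of compound 1. Compound 4 is therefore estimated at 17000 nM. Within the data shown here, the range for compound 4 is expected to run from 8000 nM to 40000 nM, the width reflecting that only a single earlier instance of the change supports the estimate.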

Compound 4, concentration for total growth inhibition: 24000 nM
For compound 4 the middle estimate is 1.4-fold (0.15 log units) below the measured one; the range from low to high includes it.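

In this assay the same replacement of hydrogen by hydroxy on the core of compound 3 gave a 1.8-fold lower number from compound 3 to compound 4 (0.25 log units; within the scatter), so on this core the two compounds cannot be told apart on this read-out. Set beside the first occurrence of the change, the new step does not differ from the earlier one, and the change can therefore be said to carry over from one core to the other within the limits of the measurement: the same change on two cores in this assay, a 2.6-fold lower number (0.41 log units; beyond the scatter) from compound 1 to compound 2 and a 1.8-fold lower number (0.25 log units; within the scatter) from compound 3 to compound 4, 1.4-fold (0.16 log units) apart, within the scatter of two such steps. Within the data shown here, this agreement rests on only two pairs, however, and since only the step on the core of compound 1 lies beyond the scatter, it does not show that hydroxy lowers the number on both cores, nor does it say why the step takes the size it does.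

What the compounds shown leave open is whether a group other than hydroxy in the same place, such as a methoxy group, an amine or a carboxylic acid, would give a step of similar size on both cores. Also open, from the compounds shown here alone, is whether the hydroxy step would hold on a third core, and which part of the difference between the two cores accounts for the gap between compound 1 and compound 3.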